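A few compounds are considered here, and "the series" means these few. Any claim that something is new, unique, unknown or untested is made for them only; others in the source may bear on it.

Compound 2, `O=C(O)Cc1sc(C(c2ccc(F)cc2)c2ccc(F)cc2)nc1-c1ccco1`, stands at the higher of the two numbers recorded in an in vitro functional assay on HEK285-7 cells for antagonist activity at prostaglandin D2 receptor 2 (Homo sapiens), read by BRET and beta-arrestin recruitment (on this read-out lower numbers stand for stronger inhibition and higher numbers for weaker inhibition), where compound 2 gives 140 nM. Its nearest neighbour is compound 1, `O=C(O)Cc1sc(C(c2ccc(F)cc2)c2ccc(F)cc2)nc1-c1cccc(F)c1`, which in this assay gives 18 nM; the step of a 7.8-fold higher number from compound 1 to compound 2 (0.89 log units; beyond the scatter) shows that swapping the six-membered ring for furan-2-yl costs potency. Compound 3, `O=C(O)Cc1sc(C(c2ccc(F)cc2)c2ccc(F)cc2)nc1-c1ccncc1`, carries the change (pyridin-4-yl in place of furan-2-yl on an aromatic carbon), restoring a six-membered aromatic ring. Among the compounds with values here, only that one step bears on the question, so a partial return toward compound 1 is expected, with a 2.3-fold lower number from compound 2 to compound 3 (0.37 log units; beyond the scatter). Compound 3 is therefore estimated at 60 nM, within 15 nM to 250 nM.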

Compound 3, half-maximal inhibitory concentration: 40 nM
Compound 3: middle estimate off by 1.5-fold (0.18 log units), on the high side, and the stated range covers the measured number.
By their numbers in this assay, from the lowest: compound 1; then compound 3; then compound 2.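

At this position, next to the ring nitrogen, the six-membered pyridin-4-yl recovers much of what furan-2-yl gave up in this assay, with a 3.5-fold lower number from compound 2 to compound 3 (0.54 log units; beyond the scatter) in that read-out. Pyridin-4-yl still falls short of 3-fluorophenyl, with a 2.2-fold higher number from compound 1 to compound 3 (0.35 log units; beyond the scatter) beyond the scatter, so these two six-membered rings are not interchangeable here. Nothing available explains this order. The compounds shown leave open how an unsubstituted phenyl would compare with 3-fluorophenyl and pyridin-4-yl. They also leave open whether pyridin-3-yl or pyridin-2-yl would match pyridin-4-yl.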